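A few compounds are considered here, and "the series" means these few. Any claim that something is new, unique, unknown or untested is made for them only; others in the source may bear on it.

Working notes on the series.

Compound 1 `O=C(CN1CCN(c2nnc(Cc3ccncc3)c3ccccc23)CC1)Nc1ccc(F)c(Cl)c1` gives the lowest number of the three measured in a functional assay on HT-29 cells (Homo sapiens) for cytotoxicity, read by MTT assay, with a stated time of 72 h (on this read-out higher numbers stand for weaker inhibition and lower numbers for stronger inhibition), at 880 nM. Compound 2 `O=C(CN1CCN(c2nnc(Cc3ccccc3)c3ccccc23)CC1)Nc1ccc(F)c(C(F)(F)F)c1` gives 4590 nM and compound 3 `O=C(CN1CCN(c2nnc(Cc3ccccc3)c3ccccc23)CC1)Nc1ccc(F)c(Cl)c1` gives 13300 nM; both lie beyond the scatter above compound 1. Two single changes are recorded. The change a 15-fold higher number from compound 1 to compound 3 (1.18 log units; beyond the scatter) is the large one and concerns the group on the saturated chain carbon, which compound 4 keeps as in compound 1. The change a 2.9-fold higher number from compound 2 to compound 3 (0.46 log units; beyond the scatter) is the modest one and concerns the substituent on the anilide ring, which is where compound 4 differs.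

Compound 4 `O=C(CN1CCN(c2nnc(Cc3ccncc3)c3ccccc23)CC1)Nc1cc(C(F)(F)F)ccc1Cl` differs from compound 1 by 2-chloro-5-(trifluoromethyl)phenyl in place of 3-chloro-4-fluorophenyl on an amide-type nitrogen. Only the change from compound 2 to compound 3 bears on this, and it compares a single substituent swap at one position, whereas here the whole substitution pattern of the ring is rearranged, so it is an indirect guide. A step of modest size in this assay is expected, most likely toward a higher number, but the direction is uncertain and the range is wide; the expected step is a 1.7-fold higher number from compound 1 to compound 4 (0.23 log units; within the scatter). Compound 4 is estimated at 1500 nM, within 400 nM to 6000 nM.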

Compound 4, half-maximal inhibitory concentration: 4810 nM
Beside the measured number, compound 4's estimate is 3.2-fold (0.51 log units) below it; the range from low to high includes it.
By their numbers in this assay, from the lowest: compound 1; then compounds 2 and 4 (each within the scatter of the next); then compound 3.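

In this assay the swap on the amide-type nitrogen gives a 5.5-fold higher number from compound 1 to compound 4 (0.74 log units; beyond the scatter) with pyridin-4-yl kept on the chain carbon, so this ring still moves the number beyond the scatter when that group is in place, and 3-chloro-4-fluorophenyl holds the lower number of the two. The earlier step of a 2.9-fold higher number from compound 2 to compound 3 (0.46 log units; beyond the scatter) left the trifluoromethyl-bearing ring on the lower side, whereas here it is on the higher side, so the presence of trifluoromethyl does not set the direction across these two pairs, which also differ in substitution pattern and in the chain group. Nothing available gives a reason for this step.

The step from compound 1 to compound 4 alters several ring substituents at once, so the share of each remains unresolved. Also open, as far as these compounds go, is whether a methoxy group or a nitrile on this ring would keep the number near that of compound 1.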